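The compounds below may be only part of what the source reports. "The series", "measured", "known", "first", "only" and "open" are said of these compounds alone.

Going by the values given here, in a physicochemical assay for lipophilicity, at pH 7.4 (on this read-out higher numbers stand for higher lipophilicity and lower numbers for lower lipophilicity), compound 2 `CC(C)(C)c1ccc(C(=O)Nc2cn3cc(F)ccc3n2)cc1` gives 3.55, the highest of the two numbers so far, and compound 1 `CNCc1ccc2nc(NC(=O)c3ccc(C(C)(C)C)cc3)cn2c1` gives 2.4. Next is compound 3 `CC(C)(C)c1ccc(C(=O)Nc2cn3cc(Cl)ccc3n2)cc1`, with chloro in place of fluoro on an aromatic carbon, two atoms from the ring nitrogen: chloro in place of fluoro on an aromatic carbon. Among the compounds with values here, the only measured step at this carbon is a number 1.15 log units higher from compound 1 to compound 2 (beyond the scatter). That step is large, but it puts fluoro in place of (methylamino)methyl and does not exchange one halogen for another. Within the data shown here, no measured step swaps fluoro for chloro, so its size gives only a loose guide here. A much smaller upward step is expected in this assay, estimated as a number 0.45 log units higher from compound 2 to compound 3 (beyond the scatter). For compound 3 the estimated value is 4, with an expected range from 3.65 to 4.35.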

Compound 3, distribution coefficient: 4.04
For compound 3 the middle estimate is 0.04 log units below the measured one, within the range that was stated.
By their numbers in this assay, from the lowest: compound 1; then compound 2; then compound 3.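

In this assay, the exchange of one halogen for the other on this aromatic carbon, two atoms from the ring nitrogen, gives a number 0.49 log units higher from compound 2 to compound 3 (beyond the scatter), so the two halogens can be told apart at this position, though the step is modest. Chloro in place of (methylamino)methyl gives a number 1.64 log units higher from compound 1 to compound 3 (beyond the scatter), so the exchange of the amine side chain for a halogen is a large step with chloro as well as with fluoro, and it exceeds the halogen exchange in size. Nothing available here bears on why the halogens differ at this carbon.

The compounds shown leave open where bromo, a nitrile or a carboxylic acid on this carbon would fall in this assay. They also leave open whether chloro in place of fluoro gives a similar step at any other carbon of the shared core.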